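The source may hold more compounds than are shown below. What is called first, only, known or untested is meant among the compounds shown, and "the series" means these compounds.

Measured so far in a functional assay on NCI-H460 cells (Homo sapiens) for cytotoxicity, read by sulforhodamine B assay, with a stated time of 48 h; on this read-out lower numbers stand for stronger inhibition of growth and higher numbers for weaker inhibition of growth:
compound 1, `COC(=O)c1sc2ccccc2c1C#Cc1ccc(OC)cc1`: > 150000 nM, a limit of the assay rather than a number
compound 2, `COC(=O)c1sc2cc(OC)ccc2c1C#Cc1ccccc1`: 54900 nM
compound 3, `COC(=O)c1sc2cc(OC)ccc2c1C#Cc1ccc(F)cc1`: 20900 nM

Compound 2 gives the highest of the two numbers in this assay; its nearest neighbour is compound 3, reached by a 2.6-fold lower number from compound 2 to compound 3 (0.42 log units; beyond the scatter). The third value, that of compound 1, is only a limit (the limit of > 150000 nM in this assay, at which 1 of the 3 values shown sits).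

Compound 4, `COC(=O)c1sc2ccccc2c1C#Cc1ccccc1`, is not yet measured. It differs from compound 2 in one place: hydrogen in place of methoxy on an aromatic carbon.

Among the compounds with values here, none of the measured steps bears directly on this change. Within the data shown here, the single measured step, from compound 2 to compound 3, concerns the other aromatic ring and adds fluoro; it says nothing about removing methoxy from the shared core. Among the measured compounds shown here, compound 1 is the only measured compound whose shared core carries no methoxy, and it gives a limit. For the measured compounds named here, compound 1 and compound 4 differ in one further place, so no step between them can be stated; their two values can only be set side by side once compound 4 is measured.

Going by the values given here, with the only unsubstituted-core compound at a limit, compound 4 is expected to sit toward the weak end, with a 2.0-fold higher number from compound 2 to compound 4 (0.30 log units; within the scatter) as the expected step. The estimate for compound 4 is 110000 nM, within 40000 nM to 300000 nM, and a fair chance that this assay returns only a limit.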

Compound 4, concentration for 50% growth inhibition: 64700 nM
For compound 4 the middle estimate is 1.7-fold (0.23 log units) above the measured one, and the stated range covers the measured number.
By their numbers in this assay, from the lowest: compound 3; then compounds 2 and 4 (each within the scatter of the next). At a limit, above all of these: compound 1.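

In this assay, the methoxy on the shared core makes no readable difference at this position: hydrogen in its place gives a 1.2-fold higher number from compound 2 to compound 4 (0.07 log units; within the scatter), so compound 2 and compound 4 cannot be told apart here. The same exchange on the other aromatic ring gives a different picture, with an at least 2.3-fold lower number from compound 1 to compound 4 (0.36 log units; beyond the scatter), so in these compounds the outcome of replacing methoxy with hydrogen depends on which ring carries the group. Compound 1 stands at a limit, so that step gives only a bound and not a size: the limit of > 150000 nM in this assay, at which 1 of the 4 values shown sits.

The compounds shown hold only methoxy or hydrogen at the core position, so it remains open whether another group there, such as an amine, a carboxylic acid or a longer alkoxy chain, would give a step beyond the scatter. Fluoro on the other aromatic ring is seen only in compound 3, which keeps the methoxy on the core, so its step of a 2.6-fold lower number from compound 2 to compound 3 (0.42 log units; beyond the scatter) remains untested on the core without methoxy.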